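A few compounds are considered here, and "the series" means these few. Any claim that something is new, unique, unknown or untested is made for them only; others in the source may bear on it.

Measured compounds:
Compound 1, `CC(C)C(Cc1ncc[nH]1)c1ccc(-c2ccc3cccc(F)c3c2)[nH]c1=O`: 11 nM
Compound 2, `Cc1c[nH]c(C(c2ccc(-c3ccc4cccc(F)c4c3)[nH]c2=O)C(C)C)n1`: 12 nM

Both numbers come from an assay on CHO cells for displacement of a labelled ligand from prostaglandin E2 receptor EP3 subtype (Homo sapiens), read by radioligand binding; a higher number here means a weaker inhibitor, a lower number a stronger inhibitor. Compound 2 and compound 1 give values that cannot be told apart, their gap being a 1.1-fold higher number from compound 1 to compound 2 (0.04 log units; within the scatter). Compound 3, `CC(C)C(/C=C1\CCNC1=O)c1ccc(-c2ccc3cccc(F)c3c2)[nH]c1=O`, is not yet measured. It differs from compound 2 by a group of 7 heavy atoms (5 carbon, 1 nitrogen, 1 oxygen; one five-membered non-aromatic ring with 1 hetero atom) in place of a group of 6 heavy atoms (4 carbon, 2 nitrogen; one five-membered aromatic ring with 2 hetero atoms), on a saturated chain carbon bound to an aromatic carbon and a saturated chain carbon: a group of 7 heavy atoms (5 carbon, 1 nitrogen, 1 oxygen; one five-membered non-aromatic ring with 1 hetero atom) in place of a group of 6 heavy atoms (4 carbon, 2 nitrogen; one five-membered aromatic ring with 2 hetero atoms), on a saturated chain carbon bound to an aromatic carbon and a saturated chain carbon. Going by the values given here, the one measured step at that position, a 1.1-fold higher number from compound 1 to compound 2 (0.04 log units; within the scatter), left the number essentially unchanged, but it kept an aromatic ring there; no measured step swaps that ring for a non-aromatic one. The expectation is therefore a modest weakening with wide uncertainty. Compound 3 is estimated at 30 nM, between 8 nM and 150 nM, an expected step of a 2.5-fold higher number from compound 2 to compound 3 (0.40 log units; beyond the scatter) in this assay.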

Compound 3, inhibition constant in the prostaglandin E2 receptor EP3 subtype assay: 2.2 nM
Beside the measured number, compound 3's estimate is 14-fold (1.13 log units) above it; measured number below the stated range.
By their numbers in the prostaglandin E2 receptor EP3 subtype assay, from the lowest: compound 3; then compounds 1 and 2 (each within the scatter of the next).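

In the prostaglandin E2 receptor EP3 subtype assay, the place on the saturated chain carbon bound to an aromatic carbon and a saturated chain carbon does not require an aromatic ring. The non-aromatic five-membered ring gives a 5.5-fold lower number from compound 2 to compound 3 (0.74 log units; beyond the scatter) and a 5.0-fold lower number from compound 1 to compound 3 (0.70 log units; beyond the scatter), whereas the earlier change between two imidazole-bearing groups gave only a 1.1-fold higher number from compound 1 to compound 2 (0.04 log units; within the scatter). In a physicochemical assay for solubility, measured as kinetic solubility, at pH 2 (on this read-out lower numbers stand for lower solubility and higher numbers for higher solubility), compound 2 gives 6300 nM and compound 3 gives 23600 nM, so the stronger binding number comes without a loss of solubility: the measured solubility of compound 2, 6300 nM, and of compound 3, 23600 nM, a 3.7-fold higher number (0.57 log units; beyond the scatter)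

The compounds shown do not separate what the ring, its carbonyl and the double bonds each contribute, as these all enter together. They also leave open how an open-chain amide or a simple amine would behave at this place in either read-out.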